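This account rests on a few compounds, and the source may have more. Where it says the series, first, only, none or still open, it means among the compounds named here.

Compound 1 `COc1cccc(CNCCCNc2ccnc3cc(Cc4cccc(C(F)(F)F)c4)ccc23)c1O` is one of two measured members of the series. In a physicochemical assay for solubility, with a stated time of 18 h, at pH 7.4 (a lower number here means a less soluble compound, a higher number a more soluble compound), compound 1 gives 4200 nM, level with compound 2. Compound 2 `FC(F)(F)c1cccc(Cc2ccc3c(NCCCNCc4ccco4)ccnc3c2)c1` gives 4200 nM, so no change at the digits printed from compound 1 to compound 2 (within the scatter) with furan-2-yl in place of 2-hydroxy-3-methoxyphenyl on a saturated chain carbon bound to an amine nitrogen. Compound 3 `COc1cccc(CNCCCNc2ccnc3cc(-c4cccc5ccccc45)ccc23)c1O` is not yet measured and differs from compound 1 by naphthalen-1-yl in place of 3-(trifluoromethyl)benzyl on an aromatic carbon. Among the measured compounds shown here, no measured step touches that aromatic carbon, so the single step seen offers no direct guide; with the two measured values level, nothing beyond the scatter is expected. Compound 3 is expected at 4000 nM, range 1500 nM to 10000 nM. The step of a 1.1-fold lower number from compound 1 to compound 3 (0.02 log units; within the scatter) is expected to stay within the scatter.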

Compound 3, solubility: 32000 nM
Compound 3: the middle estimate sits 8.0-fold (0.90 log units) below what was measured; measured number outside the range, above it.
By their numbers in this assay, from the lowest: compounds 1 and 2 (each within the scatter of the next); then compound 3.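

In this assay, among the compounds shown here, naphthalen-1-yl in place of 3-(trifluoromethyl)benzyl on the aromatic carbon of the core gives a 7.6-fold higher number from compound 1 to compound 3 (0.88 log units; beyond the scatter), the first step beyond the scatter. For the compounds shown here, the only earlier step, at the far end of the chain, gives no change at the digits printed from compound 1 to compound 2 (within the scatter), so the read-out responds at this aromatic carbon as it did not there. Nothing measured here bears on the reason for the rise.

The shown compounds do not separate the loss of trifluoromethyl from the change of benzyl to a fused aryl group, which an unsubstituted benzyl or a phenyl would address. Going by these compounds, whether the rise carries over to the furan-2-yl side chain of compound 2 also remains open.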